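The source may hold more compounds than are shown below. What is called first, only, known or untested is meant among the compounds shown, and "the series" means these compounds.

Measured compounds:
- compound 1, `COc1cc(OC)c(C2CC(c3ccco3)=NN2C(C)=O)cc1OC`: 6760 nM
- compound 2, `O=CCN1N=C(c2ccc3ccccc3c2)CC1c1ccccc1[N+](=O)[O-]`: 3480 nM

Of the compounds shown here, two have been measured in a functional assay on OVCAR cells (Homo sapiens) for cytotoxicity, read by sulforhodamine B assay, with a stated time of 48 h; a higher number here means a weaker inhibitor, a lower number a stronger inhibitor. Compound 1 gives 6760 nM and compound 2 gives 3480 nM. The gap between these two numbers lies within the scatter of repeated measurements, so compound 2 cannot be separated from compound 1 on the numbers shown; the two sit side by side rather than in any order.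

Compound 3, `O=CCN1N=C(c2ccc3ccccc3c2)CC1/C=C/c1ccccc1`, has not yet been measured in this assay. It differs from compound 2 in one place: 2-phenylethenyl in place of 2-nitrophenyl on a saturated ring carbon. The group that leaves carries the two hydrogen-bond acceptors of the nitro group; the group that enters carries none and keeps the one double bond outside aromatic rings.

Among the compounds with values here, no step between two measured compounds touches this position, so there is no measured step on which to lean. The expectation is therefore a step of no size beyond the scatter in this assay, in no particular direction, with the estimate for compound 3 set close to the number of compound 2, which is expected to change by a 1.0-fold higher number from compound 2 to compound 3 (0.00 log units; within the scatter). Compound 3 is expected to give 3500 nM, within a range from 1100 nM to 11000 nM.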

Compound 3, half-maximal inhibitory concentration: 18100 nM
Compound 3: the middle estimate sits 5.2-fold (0.71 log units) below what was measured; the whole stated range lies below it.
By their numbers in this assay, from the lowest: compounds 2 and 1 (each within the scatter of the next); then compound 3.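

In this assay, within the data shown here, the saturated ring carbon bearing the 2-nitrophenyl group proves sensitive to change: putting 2-phenylethenyl there gives a 5.2-fold higher number from compound 2 to compound 3 (0.72 log units; beyond the scatter), a step that the earlier compounds, which offered no comparison at this position, could not reveal. The exchange keeps one six-membered aromatic ring of carbon only and 1 double bond outside aromatic rings, while the hydrogen-bond acceptors of the group at this position go from 2 to 0 and the heavy atoms from 9 to 8, so a change of this kind on the shared core is enough to raise the number beyond the scatter. No measurement shown here explains the rise, and this single step cannot by itself assign it to any one feature of the exchanged groups.

The two compounds differ at this position both in the nitro group and in the ethenyl link, so the step cannot be divided between these two features. From the compounds shown here alone, a plain phenyl group at this position, or a 2-aminophenyl group in place of 2-nitrophenyl, would be needed to separate them, and how either would read in this assay remains open.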